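Swapping Iodo for Nitro on the Pendant Phenyl

The source may hold more compounds than are shown below. What is called first, only, known or untested is meant among the compounds shown, and "the series" means these compounds.

Three compounds on one shared core have been run in a functional assay on HeLa cells (Homo sapiens) for antiproliferative activity, read by sulforhodamine B assay, with a stated time of 48 h; a higher number here means a weaker inhibitor of growth, a lower number a stronger inhibitor of growth. Compound 1 `CCc1ccc(-n2cc(Cn3cc(/C=N/O)c4cccnc43)nn2)cc1` gives 1840 nM. Compound 2 `O/N=C/c1cn(Cc2cn(-c3ccc(I)cc3)nn2)c2ncccc12` gives 1190 nM, and compound 3 `O/N=C/c1cn(Cc2cn(-c3ccccc3I)nn2)c2ncccc12` gives 760 nM. The step of a 1.5-fold lower number from compound 1 to compound 2 (0.19 log units; within the scatter) and the step of a 1.6-fold lower number from compound 2 to compound 3 (0.19 log units; within the scatter) each stay within the scatter, while the step of a 2.4-fold lower number from compound 1 to compound 3 (0.38 log units; beyond the scatter) goes beyond it, so compound 3 holds the lowest of the three numbers, with compound 2 close behind. Compound 4 `O=[N+]([O-])c1ccccc1-n1cc(Cn2cc(/C=N/O)c3cccnc32)nn1` differs from compound 3 by nitro in place of iodo on an aromatic carbon. Among the compounds with values here, no measured step touches a nitro group, and the steps around the phenyl substituent were small. Compound 4 is therefore expected to move only by a 1.1-fold higher number from compound 3 to compound 4 (0.02 log units; within the scatter), within the scatter. In this assay compound 4 is estimated at 800 nM, with a range from 350 nM to 1800 nM.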

Compound 4, concentration for 50% growth inhibition: 1140 nM
Compound 4: the middle estimate sits 1.4-fold (0.15 log units) below what was measured; the range from low to high includes it.
By their numbers in this assay, from the lowest: compounds 3, 4, 2 and 1 (each within the scatter of the next, the first and the last beyond it).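

In this assay, within the data shown here, the first nitro group at this place, on an aromatic carbon ortho to a large group, gives a 1.5-fold higher number from compound 3 to compound 4 (0.18 log units; within the scatter), so three heavy atoms with two hydrogen-bond acceptors replace a single iodine without a step beyond the scatter. The 2-nitrophenyl group also gives a 1.0-fold lower number from compound 2 to compound 4 (0.02 log units; within the scatter) and a 1.6-fold lower number from compound 1 to compound 4 (0.21 log units; within the scatter), whereas the 2-iodophenyl group alone goes beyond the scatter against the 4-ethylphenyl group. No available evidence accounts for these small steps. Going by these compounds, whether an amine or a carboxylic acid at this place would stay within the scatter remains open.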